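The source may hold more compounds than are shown below. What is called first, only, known or untested is meant among the compounds shown, and "the series" means these compounds.

In a functional assay on HT-29 cells (Homo sapiens) for cytotoxicity, read by MTT assay, with a stated time of 72 h (a lower number here means a stronger inhibitor, a higher number a weaker inhibitor), compound 1 `Fc1cc(Nc2cc(Nc3ccc(Cl)cc3)ncn2)ccc1Oc1ccncc1-c1cccnc1` gives 980 nM.
Compound 2 `Fc1ccc(Nc2cc(Nc3ccc(Oc4ccncc4-c4cccnc4)c(F)c3)ncn2)cc1` gives 330 nM in this assay.
Compound 3 `O=C(Nc1ccc(Oc2ccncc2-c2cccnc2)c(F)c1)c1ccnn(-c2ccc(Cl)cc2)c1=O` gives 4560 nM in this assay.

Compound 1 and compound 2 share one core and differ by a single change, (fluoro in place of chloro on an aromatic carbon), which made a 3.0-fold lower number from compound 1 to compound 2 (0.47 log units; beyond the scatter). Compound 3 sits on a different core; the difference between the two cores is not broken down here, and compound 3 shows the highest number of the three. Compound 4 `O=C(Nc1ccc(Oc2ccncc2-c2cccnc2)c(F)c1)c1ccnn(-c2ccc(F)cc2)c1=O` carries the same change on the core of compound 3: fluoro in place of chloro on an aromatic carbon. Going by the values given here, the change is expected to move compound 4 the same way, but since only one measured pair shows it, and on another core, a smaller step is expected from compound 3 to compound 4, namely a 2.0-fold lower number from compound 3 to compound 4 (0.30 log units; within the scatter), resting on a 3.0-fold lower number from compound 1 to compound 2 (0.47 log units; beyond the scatter). For compound 4 in this assay the estimate is 2300 nM, between 1100 nM and 5000 nM.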

Compound 4, half-maximal inhibitory concentration: 4770 nM
For compound 4 the middle estimate is 2.1-fold (0.32 log units) below the measured one, and the stated range covers the measured number.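

Putting fluoro in place of chloro on the core of compound 3 gave a 1.0-fold higher number from compound 3 to compound 4 (0.02 log units; within the scatter), so this swap made no readable difference on that core. In this assay the same change therefore behaves differently on the two cores: the same change on two cores in this assay, a 3.0-fold lower number (0.47 log units; beyond the scatter) from compound 1 to compound 2 and a 1.0-fold higher number (0.02 log units; within the scatter) from compound 3 to compound 4, 3.1-fold (0.49 log units) apart, beyond the scatter of two such steps

This shows that a step seen on one core cannot simply be assumed on another in this series. Going by these compounds alone, with only two pairs, it does not show what it is about the cores that separates the steps, or how the change would behave on a third core.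

The compounds shown leave open how a group other than these two halogens, such as a methoxy or an amine at the same place on the ring, would act on either core.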